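Swapping the anilide ring: from chloro-methyl to trimethyl

The source may report more compounds than this note shows. Statements on the series, on what has been measured and on what is new or still open speak of the compounds shown alone.

Compounds and values in a functional assay on HCT-116 cells (Homo sapiens) for cytotoxicity, read by WST assay, with a stated time of 72 h; on this read-out lower numbers stand for stronger inhibition and higher numbers for weaker inhibition:
compound 1 `COc1cc2c(Nc3nc4ccc(C(=O)Nc5c(C)cccc5C)cc4s3)ncnc2cc1OCCCN1CCCCC1` – > 100000 nM
compound 2 `COc1cc2c(Nc3nc4ccc(C(=O)Nc5c(C)cc(C)cc5C)cc4s3)ncnc2cc1OCCCN1CCCCC1C` – 5600 nM
compound 3 `COc1cc2c(Nc3nc4ccc(C(=O)Nc5c(C)cccc5Cl)cc4s3)ncnc2cc1OCCCN1CCCCC1` – 23400 nM
compound 4 `COc1cc2c(Nc3nc4ccc(C(=O)Nc5c(C)cc(C)cc5C)cc4s3)ncnc2cc1OCCCN1CCCCC1` – not yet measured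

Three compounds share one core and differ in two places: the substituted phenyl ring on the amide nitrogen and the saturated ring at the end of the ether chain. Compound 1 gives only a limit, (the limit of > 100000 nM in this assay, at which 1 of the 3 values shown sits), so its value is not a number. Among the numbers that are known, compound 3 stands highest in this assay, and compound 2 sits well below it. Going by the values given here, the one measured step that can be sized runs an at least 4.2-fold lower number from compound 1 to compound 3 (0.63 log units; beyond the scatter), so exchanging the ring on the amide nitrogen changed the read-out clearly.

The change to compound 4 is 2,4,6-trimethylphenyl in place of 2-chloro-6-methylphenyl on an amide-type nitrogen. Among the compounds with values here, compound 2 carries the same trimethylphenyl group and gives a low number, though its ring at the chain end also differs from that of compound 4, so no single measured step matches the change exactly. On balance the trimethylphenyl group is expected to lower the number, and the step from compound 3 is estimated as a 2.9-fold lower number from compound 3 to compound 4 (0.47 log units; beyond the scatter). Compound 4 is therefore expected at about 8000 nM, with a plausible range from 2500 nM to 30000 nM.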

Compound 4, half-maximal inhibitory concentration: 16900 nM
Compound 4: the middle estimate sits 2.1-fold (0.32 log units) below what was measured, within the range that was stated.
By their numbers in this assay, from the lowest: compound 2; then compounds 4 and 3 (each within the scatter of the next). At a limit, above all of these: compound 1.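

In this assay, putting 2,4,6-trimethylphenyl in place of 2-chloro-6-methylphenyl on the amide-type nitrogen gives a 1.4-fold lower number from compound 3 to compound 4 (0.14 log units; within the scatter), so the two groups cannot be told apart at this position. The low number of compound 2 therefore cannot be credited to the trimethylphenyl group alone: with hydrogen in place of methyl on a saturated ring carbon, the read-out shows a 3.0-fold higher number from compound 2 to compound 4 (0.48 log units; beyond the scatter), the only clear one-place change that can be sized exactly among these new steps. The change from compound 1, methyl in place of hydrogen on an aromatic carbon, gives an at least 5.9-fold lower number from compound 1 to compound 4 (0.77 log units; beyond the scatter), but that size is only a bound, since compound 1 gives a limit and not a number: the limit of > 100000 nM in this assay, at which 1 of the 4 values shown sits.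

From the compounds shown here alone, whether the methyl on the saturated ring would have the same effect alongside the 2-chloro-6-methylphenyl group remains open, since only the trimethylphenyl pair shows it. Going by these compounds, it is also open how a methoxy group on the phenyl ring, or a dimethylamino group in place of the saturated ring at the end of the ether chain, would move the number.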